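Hydroxy meets bis-trifluoromethyl: a combination at the limit

A few compounds are considered here, and "the series" means these few. Any claim that something is new, unique, unknown or untested is made for them only; others in the source may bear on it.

Compound 1 `O=C(Nc1cccc(-n2cc(-c3ccncc3)c(-c3ccc(Cl)c(O)c3)n2)c1)Nc1cccc(C(F)(F)F)c1` reaches only the limit > 32500 nM in a functional assay on SNB-19 cells (Homo sapiens) for inhibition, read by sulforhodamine B assay, with a stated time of 48 h; a lower number here means that less compound is tolerated, a higher number that more compound is tolerated.
Compound 2 `COc1cc(-c2nn(-c3cccc(NC(=O)Nc4cc(C(F)(F)F)cc(C(F)(F)F)c4)c3)cc2-c2ccncc2)ccc1Cl` reaches only the limit > 50000 nM in this assay.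

Compound 2 thus stands at the limit of > 50000 nM in this assay, at which 1 of the 2 values shown sits, and compound 1 at the limit of > 32500 nM in this assay, at which 1 of the 2 values shown sits. Compound 3 `O=C(Nc1cccc(-n2cc(-c3ccncc3)c(-c3ccc(Cl)c(O)c3)n2)c1)Nc1cc(C(F)(F)F)cc(C(F)(F)F)c1` arises from compound 2 through (hydrogen in place of methyl on an oxygen on an aromatic ring). Among the measured compounds shown here, no step between measured compounds that differ in one place is available, so no measured size can be leaned on. Compound 3 is expected to remain at the limit because compound 2 gives (the limit of > 50000 nM in this assay, at which 1 of the 2 values shown sits). Compound 3 is therefore estimated at 60000 nM, within 20000 nM to 150000 nM. That estimate amounts to an expected step that the limit leaves unreadable from compound 2 to compound 3, nothing beyond the scatter.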

Compound 3, concentration lethal to 50% of the cells: > 50000 nM
Compound 3: only a limit was reported; the forecaster's own chance of this, stated with the estimate: 85%; the middle value lies beyond the limit too.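

Compound 1, compound 2 and compound 3 each give only a limit in this assay, so neither step to compound 3 can be read. The compounds shown leave open whether either change alters the lethal concentration at all.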